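The compounds below may be only part of what the source reports. "The series", "measured", "known", "first", "only" and "open" are said of these compounds alone.

Measured so far:
- compound 1 `C=CC1=C(C(=O)NC2CCCCC2)C(c2ccc(OC)cc2)OC1` — > 100000 nM
- compound 2 `C=CC1=C(C(=O)NCCCCC)C(c2ccc(F)cc2)OC1` — > 100000 nM
- compound 3 `C=CC1=C(C(=O)NCCCCC)C(c2ccc(OC)cc2)OC1` — 36500 nM

All three were run in a functional assay on A549 cells (Homo sapiens) for cytotoxicity, read by MTT assay, with a stated time of 24 h; on this read-out lower numbers stand for stronger inhibition and higher numbers for weaker inhibition. Compound 3 is the only one with a numerical result: in this assay compound 3 gives 36500 nM. For compound 1 the reading is a limit of the assay, > 100000 nM, not a number. For compound 2 the reading is likewise a limit, > 100000 nM.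

Two single-point changes connect the measured set. From compound 3 to compound 1 the change is cyclohexyl in place of pentyl on an amide-type nitrogen, and the step is an at least 2.7-fold higher number from compound 3 to compound 1 (0.43 log units; beyond the scatter). The cores of compound 2 and compound 3 differ by fluoro in place of methoxy on an aromatic carbon, and the step is an at least 2.7-fold lower number from compound 2 to compound 3 (0.43 log units; beyond the scatter).

Compound 4 `C=CC1=C(C(=O)NC2CCCCC2)C(c2ccc(F)cc2)OC1` has not been measured. It is reached from compound 2 by cyclohexyl in place of pentyl on an amide-type nitrogen, the same change as from compound 3 to compound 1, at a place described in the same words. On the core of compound 3 that change gave an at least 2.7-fold higher number from compound 3 to compound 1 (0.43 log units; beyond the scatter), pushing the number to the limit. Compound 2 already sits at that limit, where two of the three readings lie (the limit of > 100000 nM in this assay, at which 2 of the 3 values shown sit), so for compound 4 the expected step is a step that the limit leaves unreadable from compound 2 to compound 4 and a second limit reading is the likelier outcome. The estimate for compound 4 in this assay is 200000 nM, with an expected range of 80000 nM to 600000 nM.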

Compound 4, half-maximal inhibitory concentration: > 100000 nM
Compound 4 ended at the assay's limit (the forecaster's own chance of this, stated with the estimate: 85%); the middle value does not contradict the limit.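

Compound 4 gives > 100000 nM, a limit and not a number. The steps from compound 2 to compound 4 and from compound 1 to compound 4 cannot be read, because each pair has a limit at both ends: the limit of > 100000 nM in this assay, at which 3 of the 4 values shown sit.

Left open is whether cyclohexyl in place of pentyl on compound 2, or fluoro in place of methoxy on compound 1, shifts the reading at all.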